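Cyclohexylmethyl for 4,4-Difluorocyclohexyl on the Aromatic Nitrogen

The compounds below may be only part of what the source reports. "The series", "measured", "known", "first", "only" and "open" are said of these compounds alone.

Measured so far:
compound 1, `O=C(Cn1nnc(-c2ccccc2)n1)NC1CC2CCC1C2`, 1980 nM
compound 2, `Cc1cc(NC(=O)Cn2nnc(-c3ccccc3)n2)n(C2CCC(F)(F)CC2)n1`, 84 nM

Both were run in an assay on HEK293 cells for activation of Kir3.1/Kir3.2 (Homo sapiens), read by thallium flux; on this read-out lower numbers stand for an effect already at smaller amounts and higher numbers for an effect only at larger amounts of compound. Compound 1 gives 1980 nM in this assay, whereas compound 2 gives 84 nM, the lowest of the two numbers; its nearest neighbour is compound 1, and the gap between them lies beyond the scatter. Among the compounds with values here, the two compounds differ in more than one place, so no single step between them is recorded; their values show only that compound 2 sits well below compound 1 on this read-out.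

Compound 3, `Cc1cc(NC(=O)Cn2nnc(-c3ccccc3)n2)n(CC2CCCCC2)n1`, has not yet been measured in this assay. It departs from compound 2 in one place: cyclohexylmethyl in place of 4,4-difluorocyclohexyl on an aromatic nitrogen. Within the data shown here, no measured pair isolates this change, so nothing in the data fixes its size or direction. Since one ring-bearing group is exchanged for another on the same aromatic nitrogen, the expected step in this assay is a 2.4-fold higher number from compound 2 to compound 3 (0.38 log units; beyond the scatter), small and more likely towards a higher number than a lower one. Compound 3 is estimated at 200 nM, within 60 nM to 700 nM.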

Compound 3, half-maximal effective concentration: 176 nM
For compound 3 the middle estimate is 1.1-fold (0.06 log units) above the measured one; measured number inside the range.
By their numbers in this assay, from the lowest: compound 2; then compound 3; then compound 1.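

In this assay, within the data shown here, the exchange of 4,4-difluorocyclohexyl for cyclohexylmethyl on the aromatic nitrogen gives a 2.1-fold higher number from compound 2 to compound 3 (0.32 log units; beyond the scatter), and this is the first single-place change that can be read at this position. The position therefore has a measured sensitivity to this exchange: the step is modest, yet it lies beyond the usual scatter, and compound 3 stays at 176 nM with a six-membered carbon ring still carried on that nitrogen. Nothing available bears on why the step has this size or direction.

The exchange removes both fluorine atoms and also inserts a carbon between the ring and the aromatic nitrogen, so the compounds shown cannot divide the step between these two differences; plain cyclohexyl on that nitrogen would separate them. Also open, going by these compounds, is how this assay responds at this position to a longer chain such as cyclohexylethyl, or to a cyclohexyl ring bearing an amine or a carboxylic acid.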